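A 2-nitrophenyl swap on the sulfonyl sulfur

This account rests on a few compounds, and the source may have more. Where it says the series, first, only, none or still open, it means among the compounds named here.

Two compounds have been measured in a functional assay on U-937 cells (Homo sapiens) for cytotoxicity, read by MTT assay, with a stated time of 3 days (on this read-out higher numbers stand for weaker inhibition and lower numbers for stronger inhibition), so far:
- compound 1 `N#Cc1c(-c2ccccc2)nc(SCc2nc3ccccc3[nH]2)nc1N1CCNCC1` gives 5.81 nM
- compound 2 `Cc1ccc(S(=O)(=O)N2CCN(c3nc(SCc4nc5ccccc5[nH]4)nc(-c4ccccc4)c3C#N)CC2)cc1` gives 4.1 nM

Compound 2 stands level with compound 1 within the scatter, as shown by a 1.4-fold lower number from compound 1 to compound 2 (0.15 log units; within the scatter) between them. Compound 3 `N#Cc1c(-c2ccccc2)nc(SCc2nc3ccccc3[nH]2)nc1N1CCN(S(=O)(=O)c2ccccc2[N+](=O)[O-])CC1` carries 2-nitrophenyl in place of 4-methylphenyl on a sulfonyl sulfur and remains unmeasured. Going by the values given here, the only step bearing on this is a 1.4-fold lower number from compound 1 to compound 2 (0.15 log units; within the scatter) and that step lay within the scatter. Among the compounds with values here, no measured step exchanges the 4-methylphenyl itself, so no change beyond the scatter is expected in this assay here. The estimated step runs a 1.2-fold higher number from compound 2 to compound 3 (0.09 log units; within the scatter) and stays uncertain. Compound 3 is expected at 5 nM with an estimated range from 1.5 nM to 16 nM in this read-out.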

Compound 3, half-maximal inhibitory concentration: 3.28 nM
Estimate against measurement, compound 3: 1.5-fold (0.18 log units) above; the range from low to high includes it.
By their numbers in this assay, from the lowest: compounds 3, 2 and 1 (each within the scatter of the next).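

In this assay, the exchange on the sulfonyl sulfur gives a 1.3-fold lower number from compound 2 to compound 3 (0.10 log units; within the scatter), so 2-nitrophenyl and 4-methylphenyl cannot be told apart at this position. Against the hydrogen on the ring amine nitrogen, the new group gives a 1.8-fold lower number from compound 1 to compound 3 (0.25 log units; within the scatter), so this second sulfonyl group also stays within the scatter of the unsubstituted compound. Nothing available explains why these numbers stay so close. The compounds shown leave open whether the sulfonyl link matters, which an acetyl or benzyl group on that nitrogen would address. They also leave open how a carboxylic acid or an amine on the aromatic ring would read.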